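A few compounds are considered here, and "the series" means these few. Any claim that something is new, unique, unknown or untested is made for them only; others in the source may bear on it.

In a physicochemical assay for solubility, in phosphate buffer, measured as kinetic solubility, with a stated time of 24 h, at pH 7.4 (on this read-out higher numbers stand for higher solubility and lower numbers for lower solubility), compound 1 `O=C(NCCCNc1ccnc(Nc2cccc(NC(=O)N3CCCC3)c2)n1)C1CCC1` gives 136000 nM, compound 2 `O=C(NCCCNc1nc(Nc2cccc(NC(=O)N3CCCC3)c2)ncc1Br)C1CCC1` gives 177000 nM and compound 3 `NS(=O)(=O)c1ccc(CNc2nc(Nc3cccc(NC(=O)N4CCCC4)c3)ncc2C2CC2)cc1` gives 164000 nM. Compound 3 is not separated from the other two, as its value lies within the usual scatter of both.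

Compound 4 `O=C(NCCCNc1nc(Nc2cccc(NC(=O)N3CCCC3)c2)ncc1C1CC1)C1CCC1` shares its core with compound 3 but differs in one side chain: 2-((cyclobutylcarbonyl)amino)ethyl in place of 4-sulfamoylphenyl on a saturated chain carbon bound to a nitrogen on an aromatic ring. In words, 2-((cyclobutylcarbonyl)amino)ethyl stands in place of 4-sulfamoylphenyl on a saturated chain carbon bound to a nitrogen on an aromatic ring. Cut one bond further out, this is 4-sulfamoylbenzyl to 3-((cyclobutylcarbonyl)amino)propyl.

Among the compounds with values here, no measured pair covers this exchange directly. Within the data shown here, the only measured step, a 1.3-fold higher number from compound 1 to compound 2 (0.11 log units; within the scatter), is bromo in place of hydrogen on an aromatic carbon, and it bears on the question only indirectly. Both of its compounds carry the incoming 3-((cyclobutylcarbonyl)amino)propyl chain, and compound 2 gives 177000 nM, within the scatter of compound 3 with its 4-sulfamoylbenzyl group. No change beyond the scatter is therefore expected in this assay, in either direction.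

The expected step is a 1.1-fold lower number from compound 3 to compound 4 (0.04 log units; within the scatter), which stays within the scatter. For compound 4 the estimated value is 150000 nM, with an expected range from 95000 nM to 210000 nM.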

Compound 4, solubility: 164000 nM
The estimate for compound 4 lay 1.1-fold (0.04 log units) below the measured number; measured number inside the range.
By their numbers in this assay, from the lowest: compounds 1, 3, 4 and 2 (each within the scatter of the next).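

In this assay, 2-((cyclobutylcarbonyl)amino)ethyl in place of 4-sulfamoylphenyl on a saturated chain carbon bound to a nitrogen on an aromatic ring gives no change at the digits printed from compound 3 to compound 4 (within the scatter), so this exchange now has a measured pair of its own and, for this pair, leaves the read-out inside the scatter. With the 3-((cyclobutylcarbonyl)amino)propyl chain held constant, cyclopropyl in place of bromo on an aromatic carbon gives a 1.1-fold lower number from compound 2 to compound 4 (0.03 log units; within the scatter), and cyclopropyl as the replacement for hydrogen at that carbon gives a 1.2-fold higher number from compound 1 to compound 4 (0.08 log units; within the scatter), so hydrogen, bromo and cyclopropyl at this aromatic carbon are not separated from one another in these compounds. No measurement at hand accounts for these readings.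

The compounds shown leave open whether a side chain ending in an amine or a carboxylic acid, in place of the two chains compared here, would move the number beyond the scatter. They also leave open whether a nitrile or trifluoromethyl on the same aromatic carbon would stay within it, and whether the 4-sulfamoylbenzyl compound would read the same with hydrogen or bromo there.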